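This account rests on a few compounds, and the source may have more. Where it says the series, first, only, none or still open, it means among the compounds named here.

Compound 1 `COc1ncnc2c1c(-c1cccs1)cn2[C@@H]1O[C@H](CO)[C@@H](O)[C@H]1O` gives 70 nM in a functional assay on K562 cells (Homo sapiens), read by MTT assay, with a stated time of 72 h; a lower number here means a stronger inhibitor, a higher number a weaker inhibitor. Compound 2 `COc1nc(N)nc2c1c(-c1cccs1)cn2[C@@H]1O[C@H](CO)[C@@H](O)[C@H]1O` carries one change, (amino in place of hydrogen on an aromatic carbon), and its result is reported only as a limit of this assay, > 20000 nM, the limit described by the limit of > 20000 nM in this assay, at which 1 of the 3 values shown sits. The step is an at least 280-fold higher number from compound 1 to compound 2 (2.45 log units; beyond the scatter). Compound 3 `O=c1[nH]cnc2c1c(-c1ccco1)cn2[C@@H]1O[C@H](CO)[C@@H](O)[C@H]1O` has a different core, and the difference between the two cores is not broken down here; in this assay compound 3 gives 15500 nM. Compound 4 `Nc1nc2c(c(-c3ccco3)cn2[C@@H]2O[C@H](CO)[C@@H](O)[C@H]2O)c(=O)[nH]1` differs from compound 3 by amino in place of hydrogen on an aromatic carbon, the same kind of change as before, though here the site is meta to a group of 1 heavy atom rather than meta to a methoxy group (2 heavy atoms). For compound 4 a step of a 2.6-fold higher number from compound 3 to compound 4 (0.41 log units; beyond the scatter) is expected, resting on the large loss seen in an at least 280-fold higher number from compound 1 to compound 2 (2.45 log units; beyond the scatter). Compound 4 is therefore estimated at 40000 nM, between 15000 nM and 150000 nM.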

Compound 4, half-maximal inhibitory concentration: > 20000 nM
Compound 4 gave a limit, no number; the forecaster's own chance of this, stated with the estimate: 75%; the middle value is on the limit's open side.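

Placing amino in place of hydrogen on the core of compound 3 gives, in this assay, an at least 1.2-fold higher number from compound 3 to compound 4 (0.11 log units; that floor lies within the scatter). On both cores the amino compound reads no lower than its partner, and both sit at the same limit of the assay: the limit of > 20000 nM in this assay, at which 2 of the 4 values shown sit. This does not show that the change carries over with the same size, nor that its size depends on the core: the same change on two cores in this assay, an at least 280-fold higher number (2.45 log units; beyond the scatter) from compound 1 to compound 2 and an at least 1.2-fold higher number (0.11 log units; that floor lies within the scatter) from compound 3 to compound 4; the limit leaves it open whether they differ.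

As far as these compounds go, how far past that limit compound 2 and compound 4 lie remains open, so the true size of neither step is known. Also open, from the compounds shown here alone, is how a methylamino group, a dimethylamino group or a chlorine in place of the amino group would read on these cores.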